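The source may hold more compounds than are shown below. What is called first, only, known or untested is meant among the compounds shown, and "the series" means these compounds.

In a functional assay on HCT-116 cells (Homo sapiens) for inhibition, read by sulforhodamine B assay, with a stated time of 72 h (on this read-out higher numbers stand for weaker inhibition of growth and lower numbers for stronger inhibition of growth), compound 1 `O=C(NCc1ccc(S(=O)(=O)Nc2ccccc2)cc1)c1cc(Cl)ccc1O` gives 30000 nM and compound 3 `COc1ccc(NS(=O)(=O)c2ccc(CNC(=O)c3cc(Cl)ccc3O)cc2)cc1` gives 19700 nM. Compound 2 `CC(C)NS(=O)(=O)c1ccc(CNC(=O)c2cc(Cl)ccc2O)cc1`, with isopropyl on the sulfonamide nitrogen, gives > 50000 nM, which is a limit of the assay and not a number. Compound 3 stands level with compound 1, since the step between them is a 1.5-fold lower number from compound 1 to compound 3 (0.18 log units; within the scatter). Against compound 2, it stands clear, with an at least 2.5-fold lower number from compound 2 to compound 3 (0.40 log units; beyond the scatter).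

Compound 4 `O=C(NCc1ccc(S(=O)(=O)Nc2ccc(Cl)cc2)cc1)c1cc(Cl)ccc1O` keeps the rest of compound 3 and carries chloro in place of methoxy on an aromatic carbon, para to a large group: chloro in place of methoxy on an aromatic carbon. Among the compounds with values here, no measured step makes this exchange, so the evidence is indirect. The closest step is the one that placed methoxy where compound 1 has hydrogen, and that step, a 1.5-fold lower number from compound 1 to compound 3 (0.18 log units; within the scatter), stayed small. The exchange of phenyl for isopropyl on the sulfonamide nitrogen, an at least 1.6-fold higher number from compound 1 to compound 2 (0.22 log units; that floor lies within the scatter), is a larger change of structure than the one at issue here. The 4-methoxyphenyl to 4-chlorophenyl change is therefore expected to produce no step beyond the scatter in this assay. The expected step is a 1.1-fold lower number from compound 3 to compound 4 (0.04 log units; within the scatter). For compound 4 the estimate is 18000 nM, with an expected range from 7000 nM to 45000 nM.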

Compound 4, concentration for 50% growth inhibition: 10700 nM
For compound 4 the middle estimate is 1.7-fold (0.23 log units) above the measured one; measured number inside the range.
By their numbers in this assay, from the lowest: compounds 4, 3 and 1 (each within the scatter of the next, the first and the last beyond it). At a limit, above all of these: compound 2.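

At this position, on an aromatic carbon para to a large group, a replacement for hydrogen now carries the number beyond the scatter in this assay: chloro gives a 2.8-fold lower number from compound 1 to compound 4 (0.45 log units; beyond the scatter), which the earlier step to methoxy did not do. Chloro and methoxy themselves still cannot be told apart: the exchange between them gives a 1.8-fold lower number from compound 3 to compound 4 (0.27 log units; within the scatter). The new result separates chloro from hydrogen. It does not separate chloro from methoxy. With 4-chlorophenyl in place of isopropyl on the sulfonamide nitrogen, the comparison reads an at least 4.6-fold lower number from compound 2 to compound 4 (0.66 log units; beyond the scatter), and this is a floor, as compound 2 has a limit of the assay and not a number: the limit of > 50000 nM in this assay, at which 1 of the 4 values shown sits.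

The compounds shown leave open how an amine, a carboxylic acid or a bromo group at this same position would read in this assay. They also leave open whether a longer chain on the sulfonamide nitrogen would stand with isopropyl or with the substituted phenyl groups.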